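The source may hold more compounds than are shown below. What is called first, only, known or untested is meant among the compounds shown, and "the series" means these compounds.

In a functional assay on MCF7 cells (Homo sapiens) for inhibition, read by fluorescence, with a stated time of 72 h (a higher number here means a weaker inhibitor of growth, a lower number a stronger inhibitor of growth), compound 3 `N[C@H]1CC[C@H](Nc2nc(Nc3ccc(O)cc3)c3ncn(C4CCCCC4)c3n2)CC1` gives 9600 nM. Compound 1 `COc1ccc(Nc2nc(N[C@H]3CC[C@H](N)CC3)nc3c2ncn3CCC(C)C)c(OC)c1` gives 6300 nM. The number of compound 1 lies within the scatter of that of compound 3. Compound 2 `CC(C)CCn1cnc2c(NCc3cccc(Cl)c3)nc(N[C@H]3CC[C@H](N)CC3)nc21` gives 4700 nM. The number of compound 2 is lower than that of compound 3, by a gap that lies outside the scatter. Compound 4 `CC(C)CCn1cnc2c(Nc3ccc(O)cc3)nc(N[C@H]3CC[C@H](N)CC3)nc21` differs from compound 3 in one group: isopentyl in place of cyclohexyl on an aromatic nitrogen. This puts isopentyl in place of cyclohexyl on an aromatic nitrogen. Among the compounds with values here, no measured step tests this swap directly. Within the data shown here, the only step available, a 1.3-fold lower number from compound 1 to compound 2 (0.13 log units; within the scatter), puts 3-chlorobenzyl in place of 2,4-dimethoxyphenyl and leaves isopentyl untouched. Both of its compounds carry isopentyl, so a small shift toward their numbers in this assay is expected, with nothing beyond the scatter. The expected step is a 1.6-fold lower number from compound 3 to compound 4 (0.20 log units; within the scatter). For compound 4 the estimated value is 6000 nM, with an expected range from 2500 nM to 14000 nM.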

Compound 4, concentration for 50% growth inhibition: 3100 nM
Estimate against measurement, compound 4: 1.9-fold (0.29 log units) above; the measured number falls inside the stated range.
By their numbers in this assay, from the lowest: compounds 4, 2, 1 and 3 (each within the scatter of the next, the first and the last beyond it).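

Isopentyl in place of cyclohexyl on the aromatic nitrogen gives a 3.1-fold lower number from compound 3 to compound 4 (0.49 log units; beyond the scatter), the first direct test of this position in this assay. With isopentyl kept, 4-hydroxyphenyl in place of 3-chlorobenzyl gives a 1.5-fold lower number from compound 2 to compound 4 (0.18 log units; within the scatter), while 4-hydroxyphenyl in place of 2,4-dimethoxyphenyl gives a 2.0-fold lower number from compound 1 to compound 4 (0.31 log units; beyond the scatter). Nothing measured here explains why these numbers move. On these data alone, how a shorter chain such as ethyl, or a cyclopentyl ring, would compare on this aromatic nitrogen remains open. Also open, as far as these compounds go, is whether the isopentyl step would hold with 3-chlorobenzyl in place of 4-hydroxyphenyl.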